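This account rests on a few compounds, and the source may have more. Where it says the series, first, only, none or still open, it means among the compounds named here.

Measured so far in an assay on cell membranes for displacement of a labelled ligand from corticotropin-releasing factor receptor 1 (Rattus norvegicus); on this read-out higher numbers stand for weaker inhibition and lower numbers for stronger inhibition:
compound 1, `CCC1CCCCN1c1nc(C)nc2c(-c3c(C)cc(OC)cc3OC)c(C)nn12`, 3.26 nM
compound 2, `COCC(COC)Nc1nc(C)nc2c(-c3ccc(OC)cc3C)c(C)nn12`, 9.7 nM

Of the two numbers, compound 1 holds the lower one; compound 2 sits at a higher value, and the gap between them lies beyond the scatter. Within the data shown here, since the two compounds differ at several places at once, no single measured step exists in this set.

Compound 3, `CCCN(CCC)c1nc(C)nc2c(-c3c(C)cc(OC)cc3OC)c(C)nn12`, departs from compound 1 at one site only: dipropylamino in place of 2-ethylpiperidin-1-yl on an aromatic carbon. Everything else in the shared core and its substituents is kept as in compound 1. Among the measured compounds shown here, no measured pair shows what such an exchange does here, so the expectation rests on compound 1 alone. In this assay the step of a 1.2-fold higher number from compound 1 to compound 3 (0.09 log units; within the scatter) is expected to stay within the scatter, with no clear direction. For compound 3 the estimated value is 4 nM, with a range from 1.5 nM to 12 nM.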

Compound 3, half-maximal inhibitory concentration: 3.72 nM
Estimate against measurement, compound 3: 1.1-fold (0.03 log units) above; measured number inside the range.
By their numbers in this assay, from the lowest: compounds 1 and 3 (each within the scatter of the next); then compound 2.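

In this assay, the exchange of 2-ethylpiperidin-1-yl for dipropylamino on this aromatic carbon, between two ring nitrogen atoms, gives a 1.1-fold higher number from compound 1 to compound 3 (0.06 log units; within the scatter). Among these compounds, this is the first single-site comparison, and at this position it does not distinguish a substituent holding a six-membered non-aromatic ring from one with no ring, at least with the rest of compound 1 kept in place. No measurement on hand explains why the two groups read alike.

Still open, from the compounds shown here alone, is whether this tolerance extends to a longer chain such as dibutylamino, or to a ring with a second hetero atom such as morpholin-4-yl. Going by these compounds, it is also open whether a secondary amine, with a hydrogen on the nitrogen, would read alike on the aryl group of compound 1.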